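A few compounds are considered here, and "the series" means these few. Any claim that something is new, unique, unknown or untested is made for them only; others in the source may bear on it.

Among the compounds with values here, in a physicochemical assay for solubility, in phosphate buffer, at pH 7.4 (on this read-out lower numbers stand for lower solubility and higher numbers for higher solubility), compound 2 `CC(=O)N[C@@H]1CCC[C@H](C(=O)Nc2cc(-c3cnc4ccccn34)c(Cl)cn2)C1` gives 120000 nM and compound 3 `CC(=O)N[C@@H]1CCC[C@H](C(=O)Nc2cc(-c3cnn4c3CCC4)c(Cl)cn2)C1` gives 160000 nM, so compound 2 stands within the scatter of the only other number available. Compound 1 `CC(=O)N[C@@H]1CCC[C@H](C(=O)Nc2cc(-c3cnn4c3CCCC4)c(F)cn2)C1` reads > 1000000 nM, which is a limit of this assay and not a number. Compound 4 `CC(=O)N[C@@H]1CCC[C@H](C(=O)Nc2cc(-c3cnn4c3OCCC4)c(Cl)cn2)C1` has not yet been measured. It differs from compound 2 on an aromatic carbon ortho to a chloro group and opposite the ring nitrogen: a group of 9 heavy atoms (6 carbon, 2 nitrogen, 1 oxygen; one five-membered aromatic ring with 2 hetero atoms, one six-membered non-aromatic ring with 2 hetero atoms) in place of a group of 9 heavy atoms (7 carbon, 2 nitrogen; one five-membered aromatic ring with 2 hetero atoms, one six-membered aromatic ring with 1 hetero atom), on an aromatic carbon. Within the data shown here, the group that leaves is the same one that leaves in the only measured step bearing on this change, which is a 1.3-fold higher number from compound 2 to compound 3 (0.12 log units; within the scatter). That single step is all the guidance there is, and it replaces the group with a different one from that in compound 4. Because a 1.3-fold higher number from compound 2 to compound 3 (0.12 log units; within the scatter) stayed within the scatter, no change beyond the scatter is expected for compound 4. The expected step is a 1.5-fold higher number from compound 2 to compound 4 (0.18 log units; within the scatter). For compound 4 the estimated value is 180000 nM, with an expected range from 70000 nM to 500000 nM.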

Compound 4, solubility: 110000 nM
Beside the measured number, compound 4's estimate is 1.6-fold (0.21 log units) above it; the range from low to high includes it.
By their numbers in this assay, from the lowest: compounds 4, 2 and 3 (each within the scatter of the next). At a limit, above all of these: compound 1.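

In this assay, this place on an aromatic carbon, ortho to a chloro group and opposite the ring nitrogen, now has a second replacement for the group of compound 2, and it also stays within the scatter: the result is a 1.1-fold lower number from compound 2 to compound 4 (0.04 log units; within the scatter) and, against the other replacement, a 1.5-fold lower number from compound 3 to compound 4 (0.16 log units; within the scatter) in the same assay. With the chloro group held, the three different groups in compounds 2, 3 and 4 therefore give values that cannot be told apart, and this now includes a six-membered non-aromatic ring with 2 hetero atoms, one of them oxygen. Nothing shown gives a cause for this result.

Compound 1 reads > 1000000 nM and this is a limit of the assay, not a number, so it cannot be placed against the others, from which it differs in more than one place. Still open, on these data alone, is whether fluorine in place of the chloro group on its own, or an amine on the entering ring, would move the number beyond the scatter.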